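The compounds below may be only part of what the source reports. "The series", "measured", "known", "first", "only" and "open" are said of these compounds alone.

Among the compounds with values here, compound 2 `ClCc1cccc(Cn2cnc3ncnc(Cl)c32)c1` is one of two compounds measured in a functional assay on U-251 cells (Homo sapiens) for cytotoxicity, read by sulforhodamine B assay, with a stated time of 48 h; a higher number here means that more compound is tolerated, a lower number that less compound is tolerated. Compound 2 gives > 100000 nM, which is a limit of the assay rather than a measured number. Compound 1 `ClCc1ccccc1Cn1cnc2c(Cl)nc(Cl)nc21`, in this assay, gives 4570 nM. The relevant piece of evidence is the limit of > 100000 nM in this assay, at which 1 of the 2 values shown sits, so compound 2 stands at the edge of what the assay reports, while compound 1 stands at a measured number.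

Compound 3 `ClCc1cccc(Cn2cnc3nc(Cl)nc(Cl)c32)c1` has not yet been measured. It differs from compound 2 by chloro in place of hydrogen on an aromatic carbon. No measured step between two compounds covers this change, so the expectation rests on what is shown: compound 1, which already carries the chloro that enters here, gives 4570 nM, a measured number rather than a limit. On that basis the step from compound 2 to compound 3 in this assay is expected to go toward a lower number, beyond the scatter, by an at least 8.3-fold lower number from compound 2 to compound 3 (0.92 log units; beyond the scatter). Compound 3 is estimated at 12000 nM, with a range from 3000 nM to 60000 nM.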

Compound 3, concentration lethal to 50% of the cells: 5120 nM
The estimate for compound 3 lay 2.3-fold (0.37 log units) above the measured number; measured number inside the range.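

In this assay, chloro in place of hydrogen on the aromatic carbon between two ring nitrogen atoms gives an at least 19-fold lower number from compound 2 to compound 3 (1.29 log units; beyond the scatter), with the rest of the molecule unchanged. Within the data shown here, compound 1 already carried this chloro but also differed from compound 2 elsewhere, so this pair is the first to tie a large change to this position alone; compound 1 at 4570 nM and compound 3 at 5120 nM lie within the usual scatter of each other. The true size of the step stays unknown, and only its minimum can be read, as one end of it is a limit: the limit of > 100000 nM in this assay, at which 1 of the 3 values shown sits.

The compounds shown leave open whether the effect belongs to chloro itself or whether another group on this carbon, such as an amine, a methoxy or a fluoro, would give a similar number in this assay. They also leave open how a compound carrying this chloro would respond if the chloromethyl group gave way to a plain methyl, and how far compound 2 actually lies beyond its limit.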